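Pyrrolidin-1-yl for 4-methylpiperazin-1-yl in compound 1

The compounds below may be only part of what the source reports. "The series", "measured", "known", "first", "only" and "open" are said of these compounds alone.

Measured in a functional assay on BCG823 cells (Homo sapiens) for antiproliferative activity, read by MTT assay, with a stated time of 48 h; a higher number here means a weaker inhibitor, a lower number a stronger inhibitor:
- compound 1 `COc1cc2oc(-c3ccccc3)cc(=O)c2c(O)c1OCCCCN1CCN(C)CC1`: 53500 nM
- compound 2 `CN1CCN(CCCCOc2c(OCc3ccccc3)cc3oc(-c4ccccc4)cc(=O)c3c2O)CC1`: 7200 nM

Compound 1 stands highest of the two numbers. Going by the values given here, the only measured step, a 7.4-fold lower number from compound 1 to compound 2 (0.87 log units; beyond the scatter), comes with phenyl in place of hydrogen on a saturated chain carbon bound to an oxygen on an aromatic ring. Compound 3 `COc1cc2oc(-c3ccccc3)cc(=O)c2c(O)c1OCCCCN1CCCC1` differs at another place: pyrrolidin-1-yl in place of 4-methylpiperazin-1-yl on a saturated chain carbon, four bonds along the chain from an oxygen on an aromatic ring. Here pyrrolidin-1-yl stands in place of 4-methylpiperazin-1-yl, four bonds along the chain from an oxygen on an aromatic ring. Among the compounds with values here, no measured pair covers this exchange, so the one step bears on it only as a rough guide to size. A modest step towards a lower number is expected in this assay, since compound 1 at 53500 nM has the higher value. The expected step is a 1.8-fold lower number from compound 1 to compound 3 (0.25 log units; within the scatter). For compound 3 the estimate is 30000 nM, with an expected range of 10000 nM to 80000 nM.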

Compound 3, half-maximal inhibitory concentration: 10600 nM
Compound 3: middle estimate off by 2.8-fold (0.45 log units), on the high side; the range from low to high includes it.
By their numbers in this assay, from the lowest: compounds 2 and 3 (each within the scatter of the next); then compound 1.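

In this assay this position is not silent: pyrrolidin-1-yl in place of 4-methylpiperazin-1-yl, on a saturated chain carbon four bonds along the chain from an oxygen on an aromatic ring, gives a 5.0-fold lower number from compound 1 to compound 3 (0.70 log units; beyond the scatter). Going by these compounds alone, until now the only step on record, a 7.4-fold lower number from compound 1 to compound 2 (0.87 log units; beyond the scatter), lay at another place, so a second site now moves the number beyond the scatter. Nothing given here explains the step at this position.

The exchange alters ring size and hetero atom count together, and piperidin-1-yl or morpholin-4-yl would be needed to separate the two. Also open, from the compounds shown here alone, are the effect of a shorter or longer chain and whether pyrrolidin-1-yl gives a similar step on the core of compound 2.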